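A few compounds are considered here, and "the series" means these few. Any claim that something is new, unique, unknown or untested is made for them only; others in the source may bear on it.

Compound 1 `Cn1cc(-c2cncc(-c3ccc(C(N)=O)cc3)c2)cn1`: 800 nM
Compound 2 `NC(=O)c1ccc(-c2cccnc2)cc1Cl`: 11000 nM

In an assay on cells for inhibition of MAP kinase-interacting serine/threonine-protein kinase 1 (Homo sapiens), read by mobility shift assay, with stated times of 10 min and 60 min, in the presence of a further agent that is not named here (a lower number here means a stronger inhibitor, a higher number a weaker inhibitor), compound 1 gives 800 nM, and compound 2 gives 11000 nM. Of these two numbers, compound 2 has the higher one, so it is the weaker inhibitor of the pair, and the gap between the two values lies beyond the usual scatter of such measurements. Compound 3 `NC(=O)c1ccc(-c2cccnc2)cc1OC1CCCCC1` has not yet been tested. It differs from compound 2 in a single place: cyclohexyloxy in place of chloro on an aromatic carbon. Among the compounds with values here, no pair of measured compounds shows this same change, so there is no measured step to lean on here. A modest shift toward a lower number is expected, of a size at about the edge of the scatter. For compound 3 the estimate in this assay is 4000 nM, with a range from 1000 nM to 20000 nM. That estimate means an expected step of a 2.8-fold lower number from compound 2 to compound 3 (0.44 log units; beyond the scatter).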

Compound 3, half-maximal inhibitory concentration: 1500 nM
Compound 3: the middle estimate sits 2.7-fold (0.43 log units) above what was measured; low and high end bracket the measured number.
By their numbers in this assay, from the lowest: compounds 1 and 3 (each within the scatter of the next); then compound 2.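

In this assay, the aromatic carbon ortho to a carbamoyl group takes much more than a single chlorine: cyclohexyloxy brings 7 heavy atoms and a six-membered non-aromatic ring, and inhibition still improves (a 7.3-fold lower number from compound 2 to compound 3 (0.87 log units; beyond the scatter)). Within the data shown here, this is the first measured evidence on this position, and it shows that chloro is not needed there for inhibition and that the larger group is the better of the two. Nothing measured here accounts for the size of this step.

On these data alone, whether the gain comes from the oxygen link or from the ring stays open, and a methoxy group, a cyclohexyl group or a cyclohexylamino group at this place would help separate the two. Also open, as far as these compounds go, is whether cyclohexyloxy would give a similar step on the core of compound 1.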